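Three tolerated amides, a fourth awaits its reading

The compounds below may be only part of what the source reports. "The series", "measured", "known", "first", "only" and "open" are said of these compounds alone.

Compound 1 `CNC(=O)c1c(NO)cc(-c2ccc(Cl)cc2)oc1=O` and compound 2 `CNC(=O)c1c(NO)cc(-c2ccc(C)cc2)oc1=O` share one core; the two differ only in methyl in place of chloro on an aromatic carbon. Compound 3 `COC(=O)CNC(=O)c1c(NO)cc(-c2ccc(Cl)cc2)oc1=O` keeps the core of compound 1 and differs from it by methoxycarbonyl in place of hydrogen on a saturated chain carbon bound to an amide-type nitrogen. In an ADME assay on Huh-7 cells (Homo sapiens) for cytotoxicity, read by a luciferase reporter and WST assay, with a stated time of 3 days (a higher number here means that more compound is tolerated, a lower number that less compound is tolerated), compound 1 does not reach a number and stops at the limit of the assay, > 20000 nM. In this assay compound 2 also ends at the limit, > 20000 nM. In this assay compound 3 again gives only the limit, > 20000 nM. The step that the two limits leave unreadable from compound 1 to compound 2 therefore has no readable size, because of the limit of > 20000 nM in this assay, at which 3 of the 3 values shown sit. The same is true of a step that the two limits leave unreadable from compound 1 to compound 3, which cannot be sized because of the limit of > 20000 nM in this assay, at which 3 of the 3 values shown sit.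

Compound 4 `COC(=O)CNC(=O)c1c(NO)cc(-c2ccc(C)cc2)oc1=O` has not yet been run. It stands to compound 3 as compound 2 stands to compound 1: the change is methyl in place of chloro on an aromatic carbon, and the surroundings of the exchanged atom read the same in both pairs, so this is the same change made a second time; the two cores differ from each other by the change between compound 1 and compound 3 described above. With every measured value resting at the limit, a reading at the limit is the expectation for compound 4 as well. In this assay compound 4 is expected to give 30000 nM, with a likely span from 15000 nM to 80000 nM. The estimated step that the limit leaves unreadable from compound 3 to compound 4 rests on a step that the two limits leave unreadable from compound 1 to compound 2, the same change made once before. In that earlier pair compound 1 gives only the limit, > 20000 nM. Compound 2 likewise gives only the limit, > 20000 nM.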

Compound 4, half-maximal cytotoxic concentration: > 20000 nM
Compound 4 ended at the assay's limit (the forecaster's own chance of this, stated with the estimate: 85%); the middle value lies beyond the limit too.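

No step can be read between compound 3 and compound 4 or between compound 2 and compound 4 in this assay, and the cause is one shared reading: the limit of > 20000 nM in this assay, at which 4 of the 4 values shown sit.

Still open, on these data alone, is whether methyl in place of chloro, or methoxycarbonyl in place of hydrogen, changes the tolerated concentration at all, and at what concentration any of the four compounds would give a number in this assay.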